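The source may report more compounds than this note shows. Statements on the series, on what has been measured and on what is new or still open speak of the compounds shown alone.

Measured compounds:

Compound 1, `CCC1=C(C(=O)CC2CCCC2)[C@H](c2ccc(O)c(Cl)c2)NC(=O)N1`. In an ADME assay on cells (Homo sapiens) for cytotoxicity (on this read-out higher numbers stand for lower toxicity in this test and lower numbers for higher toxicity in this test), compound 1 gives > 10000 nM, which is a limit of the assay and not a number.
Compound 2, `CCC1=C(C(=O)CC2CCCCC2)[C@H](c2ccc(O)c(Cl)c2)NC(=O)N1`. In this assay compound 2 gives > 10000 nM, again a limit of the assay.
Compound 3, `CCC1=C(C(=O)CC2CCC(C)CC2)[C@H](c2ccc(O)c(Cl)c2)NC(=O)N1`. In this assay compound 3 gives > 10000 nM, also a limit of the assay.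

Compound 3 thus stands at the same limit as the other two; the three values together are described by the limit of > 10000 nM in this assay, at which 3 of the 3 values shown sit. The steps among them are a step that the two limits leave unreadable from compound 1 to compound 2, a step that the two limits leave unreadable from compound 1 to compound 3 and a step that the two limits leave unreadable from compound 2 to compound 3. None of them can be read in size. Every value is only a limit.

The next compound, compound 4, `CCC1=C(C(=O)CC2CCC(C(C)C)CC2)[C@H](c2ccc(O)c(Cl)c2)NC(=O)N1`, differs from compound 3 by isopropyl in place of methyl on a saturated ring carbon. The measured steps that bear on this change are those growing the ring group, and they are all unreadable. Given that compound 3 sits at the limit, compound 4 is expected to stay there as well, the step that the limit leaves unreadable from compound 3 to compound 4 being an expectation only. The estimate for compound 4 in this assay is 15000 nM, within 6000 nM to 40000 nM.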

Compound 4, half-maximal cytotoxic concentration: > 10000 nM
Compound 4: only a limit was reported; the forecaster's own chance of this, stated with the estimate: 80%; the middle value does not contradict the limit.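

Compound 4, like compounds 1, 2 and 3, gives only a limit and not a number, so no step among these four compounds can be read in size: the limit of > 10000 nM in this assay, at which 4 of the 4 values shown sit.

From the compounds shown here alone, whether any of these ring groups changes the cytotoxicity of the compounds remains open, since a real value for any of them is lacking in this assay.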